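Swapping the aryl group on the shared core of compound 2

The compounds below may be only part of what the source reports. "The series", "measured", "known", "first", "only" and "open" are said of these compounds alone.

Measured so far in a physicochemical assay for acid dissociation:
Compound 1 `COc1ccc(F)cc1CNCCCNc1ccnc2cc(-c3ccc(C(C)(C)C)cc3)ccc12` gives 9.47.
Compound 2 `COc1ccc(F)cc1CNCCCNc1ccnc2cc(Oc3ccc(Cl)cc3)ccc12` gives 9.28.

Within the data shown here, compound 2 has the lower of the two numbers, with compound 1 the only neighbour, and the gap between them lies within the scatter: the only measured step, a number 0.19 log units lower from compound 1 to compound 2 (within the scatter), shows that exchanging the group on this aromatic carbon left this assay essentially unchanged.

Compound 3 `COc1ccc(F)cc1CNCCCNc1ccnc2cc(-c3ccc(C(F)(F)F)cc3)ccc12` changes the same place once more: 4-(trifluoromethyl)phenyl in place of 4-chlorophenoxy on an aromatic carbon.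

Among the measured compounds shown here, the step from compound 1 to compound 2 is the one measured change at this position, and it stayed within the scatter. For the measured compounds named here, no other step is available. On that basis compound 3 is expected to sit close to compound 2 in this assay, with the estimated step of a number 0.12 log units higher from compound 2 to compound 3 (within the scatter) not reaching beyond the scatter. Compound 3 is therefore estimated at 9.4, within a range from 9.1 to 9.7.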

Compound 3, acid dissociation constant: 9.47
Compound 3: the middle estimate sits 0.07 log units below what was measured, and the stated range covers the measured number.
By their numbers in this assay, from the lowest: compounds 2, 1 and 3 (each within the scatter of the next).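

In this assay, a third group now stands on this aromatic carbon, and 4-(trifluoromethyl)phenyl in place of 4-chlorophenoxy gives a step that stays inside the scatter (a number 0.19 log units higher from compound 2 to compound 3 (within the scatter)). The new pair with compound 1 is the cleaner comparison: both keep a phenyl ring on the core and differ only in the group that ring carries, and trifluoromethyl in place of tert-butyl leaves the number as it was (no change at the digits printed from compound 1 to compound 3 (within the scatter)), so neither that exchange nor the oxygen of the 4-chlorophenoxy group in compound 2 takes the read-out outside the scatter. Nothing at hand explains why the number holds so steady across these three groups.

All three groups shown contain one six-membered aromatic ring of carbon only, so it stays open whether the number would hold with an amine or a carboxylic acid on that ring, or with a plain hydrogen on the core in place of the ring. Nor do these compounds tell whether the number would respond to a change at another place, such as a longer chain in the side arm that all three share.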